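Methyl on the pendant phenyl: two limits and an untested pair

The source may report more compounds than this note shows. Statements on the series, on what has been measured and on what is new or still open speak of the compounds shown alone.

Measured compounds
- Compound 1, `Cc1ccc(-c2cc(/N=C3/NC(=O)CS3)cs2)cc1`: in a functional assay on SW-620 cells (Homo sapiens) for cytotoxicity, read by MTT assay, with a stated time of 72 h (on this read-out higher numbers stand for weaker inhibition and lower numbers for stronger inhibition), compound 1 gives > 50000 nM, which is a limit of the assay and not a number.
- Compound 2, `O=C1CS/C(=N\c2csc(-c3ccccc3)c2)N1`: in this assay compound 2 gives > 50000 nM, again a limit of the assay rather than a number.

Compound 2 differs from compound 1 by methyl in place of hydrogen on an aromatic carbon. Because both values are limits, the step that the two limits leave unreadable from compound 2 to compound 1 cannot be read in size; this rests on (the limit of > 50000 nM in this assay, at which 2 of the 3 values shown sit).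

Compound 3, `O=C1CS/C(=N\c2csc(-c3ccc(Cl)cc3)c2)N1c1ccccc1`, has no reported result: in this assay compound 3 gives "not determined" (no result reported). How the core of compound 3 differs from the core of compound 2 is not broken down here. Compound 4, `Cc1ccc(N2C(=O)CS/C2=N\c2csc(-c3ccc(Cl)cc3)c2)cc1`, is not yet measured. Compound 4 differs from compound 3 by methyl in place of hydrogen on an aromatic carbon. Going by the values given here, this is the same kind of change as the one from compound 2 to compound 1, though not the same: for compound 3 to compound 4 the difference, cut one bond further out, reads phenyl to 4-methylphenyl.

Among the compounds with values here, since the one measured step of this kind is unreadable and compound 3 has no value, the expectation for compound 4 rests only on both measured compounds sitting at the limit. Compound 4 is estimated at 60000 nM, expected to fall between 20000 nM and 200000 nM, most likely reported again as a limit.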

Compound 4, half-maximal inhibitory concentration: > 50000 nM
Compound 4: a limit, no number; the forecaster's own chance of this, stated with the estimate: 75%; the middle value is on the limit's open side.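

In this assay compound 4 gives > 50000 nM, which is a limit of the assay and not a number. Compound 3 gives "not determined" (no result reported), so no step can be read from compound 3 to compound 4. Whether swapping hydrogen for methyl changes cytotoxicity at all stays open, as does where any of these compounds would fall as an actual number; what the compounds shown offer is only this: the limit of > 50000 nM in this assay, at which 3 of the 4 values shown sit.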